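The compounds below may be only part of what the source reports. "The series", "measured", "known", "first", "only" and "open" are said of these compounds alone.

Measured compounds:
- compound 1, `CC(C)[C@@H](C(=O)Nc1ccc(C(=O)Nc2ccccc2N)cc1)c1ccccc1` — in an assay on isolated protein for inhibition of histone deacetylase 7 (Homo sapiens), tested at 1 uM (a higher number here means more inhibition at the concentration tested (going by the name of the read-out), a lower number less inhibition), compound 1 gives 9%
- compound 2, `CC(C)[C@H](C(=O)Nc1ccc(C(=O)Nc2ccccc2N)cc1)c1ccccc1` — in this assay compound 2 gives 1%

Compound 1 stands highest of the two numbers shown, but its nearest neighbour is compound 2, and the step of a number 8 percentage points lower from compound 1 to compound 2 (within the scatter) lies within the scatter, so the two cannot be ordered. That step rests on the fact that compounds 1 and 2 differ only in the configuration as drawn alone, and it shows that turning the configuration at the saturated chain carbon does not move the read-out in this assay beyond the scatter.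

Compound 3, `CC(C)[C@@H](C(=O)Nc1ccc(C(=O)Nc2ccc(F)cc2N)cc1)c1ccccc1`, is not yet measured. It differs from compound 1 by fluoro in place of hydrogen on an aromatic carbon. For the measured compounds named here, no measured step touches that part of the molecule: the single step on record concerns only the configuration at the chain carbon, not a substituent on the aromatic ring carrying the amino group. There is therefore nothing to suggest a step in either direction beyond the scatter in this assay, and a change of the size a number 1 percentage points higher from compound 1 to compound 3 (within the scatter) is expected. Compound 3 is estimated to give 10% in this assay, within 0% to 25%.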

Compound 3, a percentage reported as inhibition, at one concentration (the size of the read-out at that concentration, not a potency): 0%
For compound 3 the middle estimate is 10 percentage points above the measured one; low and high end bracket the measured number.
By their numbers in this assay, from the lowest: compounds 3, 2 and 1 (each within the scatter of the next).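

For the compounds shown here, with this result the ring carrying the amino group enters the comparison for the first time; until now, the only step on record concerned the configuration at the chain carbon. In this assay, the step for fluoro in place of hydrogen, at the position meta to an amino group and para to a large group, is a number 9 percentage points lower from compound 1 to compound 3 (within the scatter) and so gives no ordering of the two compounds, which means that this single change, at this one position, shows no effect that can be told from the scatter. The one fact on record about these compounds concerns configuration and has no bearing on this ring position, so no cause can be given for the result.

The compounds shown leave open whether a larger or differently built group at this same aromatic carbon, such as chloro, methoxy or a carboxylic acid, would give a step beyond the scatter in this assay. They also leave open what fluoro does at the other carbons of this ring, and whether a longer chain at the saturated chain carbon would move the read-out.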